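Chloro for hydrogen on the core: a repeated step

This account rests on a few compounds, and the source may have more. Where it says the series, first, only, none or still open, it means among the compounds named here.

Measured compounds:
compound 1 `ClCc1cccc(Cn2cnc3ncnc(Cl)c32)c1`, 3310 nM
compound 2 `ClCc1ccccc1Cn1cnc2ncnc(Cl)c21`, 11200 nM
compound 3 `ClCc1cccc(Cn2cnc3nc(Cl)nc(Cl)c32)c1`, 35500 nM

Compounds 1 and 2 share the same atoms joined differently; the difference between the two cores is not broken down here. In a functional assay on KM12 cells (Homo sapiens) for cytotoxicity, read by sulforhodamine B assay, with a stated time of 48 h (a higher number here means a weaker inhibitor of growth, a lower number a stronger inhibitor of growth), compound 2 sits between the other two, with compound 1 giving the lowest number and compound 3 the highest. From compound 1 to compound 3 the change is chloro in place of hydrogen on an aromatic carbon, and it made the step of an 11-fold higher number from compound 1 to compound 3 (1.03 log units; beyond the scatter).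

Compound 4 `ClCc1ccccc1Cn1cnc2nc(Cl)nc(Cl)c21` is not yet measured. It differs from compound 2 by chloro in place of hydrogen on an aromatic carbon, the same change at the same place as from compound 1 to compound 3. Going by the values given here, with only one earlier instance to rest on, the step is expected to be of similar size, an 8.9-fold higher number from compound 2 to compound 4 (0.95 log units; beyond the scatter), weakening growth inhibition. Compound 4 is therefore estimated at 100000 nM in this assay, between 40000 nM and 250000 nM, and a limit rather than a number is a real possibility.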

Compound 4, concentration for total growth inhibition: 25700 nM
Beside the measured number, compound 4's estimate is 3.9-fold (0.59 log units) above it; the whole stated range lies above it.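

In this assay, chloro in place of hydrogen on the aromatic carbon between two ring nitrogen atoms gives a 2.3-fold higher number from compound 2 to compound 4 (0.36 log units; beyond the scatter). The direction of the step carries over to the second core, but its size does not: the same change on two cores in this assay, an 11-fold higher number (1.03 log units; beyond the scatter) from compound 1 to compound 3 and a 2.3-fold higher number (0.36 log units; beyond the scatter) from compound 2 to compound 4, 4.7-fold (0.67 log units) apart, beyond the scatter of two such steps. Going by these compounds alone, two pairs show only that the number rose on both of these cores; they do not show that it would rise on any other core, and they do not explain why the two step sizes differ.

Still open, going by these compounds, is whether an amine or a methoxy group in place of this chloro would move the number in the same direction on both cores, and whether the two steps would again differ in size.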